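This account rests on a few compounds, and the source may have more. Where it says the series, first, only, none or still open, it means among the compounds named here.

Of the compounds shown here, three have been tested in a functional assay on the whole organism (strain Wistar Albino) for inhibition, with Rattus norvegicus as the target, read by paw edema, with a stated time of 2 h, at a dose of 20 mg/kg; on this read-out lower numbers stand for less inhibition and higher numbers for more inhibition at the one dose given (going by the name of the read-out). Compound 1 `Cc1cc(-c2nn3c(-c4ccoc4C)nnc3s2)c2ccccc2n1` gives 13.4% in this assay. Compound 2 `Cc1occc1-c1nnc2sc(-c3ccnc(F)c3)nn12` gives 18.2% in the same assay. Compound 3 `COc1ccc(Cl)c(-c2nnc3sc(Cc4c[nH]c5ccc(OC)cc45)nn23)c1` gives 14.4% in this assay, a number that falls between those of compound 1 and compound 2, with every gap among the three within the usual scatter of repeated measurements, so none of the three numbers can be called higher or lower than another.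

Compound 4 `COc1ccc2[nH]cc(Cc3nn4c(-c5ccoc5C)nnc4s3)c2c1` has not yet been measured. It differs from compound 3 at one place: 2-methylfuran-3-yl in place of 2-chloro-5-methoxyphenyl on an aromatic carbon. The group that enters is the same group carried by compound 1 and compound 2, whose numbers in this assay sit close to that of compound 3. No change between two measured compounds that differ at only one place is available to guide the step, so the expectation rests on the narrow spread of the three numbers. The step from compound 3 to compound 4 is expected to be small, a number 0.6 percentage points higher from compound 3 to compound 4 (within the scatter), in no clear direction and not beyond the scatter. Compound 4 is therefore estimated at 15% in this assay, within a range from 6% to 25%.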

Compound 4, a percentage reported as inhibition, in the whole organism at one dose (the size of the read-out at that dose, not a potency): 20.1%
The estimate for compound 4 lay 5.1 percentage points below the measured number; the range from low to high includes it.
By their numbers in this assay, from the lowest: compounds 1, 3, 2 and 4 (each within the scatter of the next).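

In this assay, putting 2-methylfuran-3-yl in place of 2-chloro-5-methoxyphenyl on the aromatic carbon between two ring nitrogen atoms gives a number 5.7 percentage points higher from compound 3 to compound 4 (within the scatter). For the compounds shown here, this is the first direct comparison at this position, and it shows that a six-membered aromatic ring of carbon only can be exchanged for a five-membered aromatic ring with one hetero atom without a change that stands clear of the scatter. No measurement is available that would explain the size of this step.

These two aromatic rings say little about how a very different group at this carbon, such as an amine, a carboxylic acid or a longer alkyl chain, would behave in this assay. On these data alone, it also remains open whether the same exchange would give a similar step on a compound with a different group at the other end of the core.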